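Fluorine Pattern on the Benzyl Group and Cell Tolerance

The compounds below may be only part of what the source reports. "The series", "measured", "known", "first", "only" and "open" are said of these compounds alone.

Three compounds share one core and differ only in the fluorine pattern of their benzyl group. Compound 1 `CCOC(=O)/C(O)=C/C(=O)c1cn(Cc2ccc(F)c(F)c2F)c2cccc(OC)c12` gives 42700 nM in an ADME assay on MT4 cells (Homo sapiens) for cytotoxicity, read by MTT assay; a higher number here means that more compound is tolerated, a lower number that less compound is tolerated. Compound 2 `CCOC(=O)/C(O)=C/C(=O)c1cn(Cc2c(F)ccc(F)c2F)c2cccc(OC)c12` gives 40500 nM. Compound 3 `CCOC(=O)/C(O)=C/C(=O)c1cn(Cc2cccc(F)c2)c2cccc(OC)c12` gives 63200 nM. The steps of a 1.5-fold higher number from compound 1 to compound 3 (0.17 log units; within the scatter) and a 1.6-fold higher number from compound 2 to compound 3 (0.19 log units; within the scatter) stay within the scatter, as does a 1.1-fold lower number from compound 1 to compound 2 (0.02 log units; within the scatter), so the three numbers sit together rather than apart. Compound 4 `CCOC(=O)/C(O)=C/C(=O)c1cn(Cc2cc(F)ccc2F)c2cccc(OC)c12` differs from compound 3 by fluoro in place of hydrogen on an aromatic carbon. Every measured step likewise only rearranged fluorine on this ring, and none moved the number beyond the scatter, so the expected step is a 1.1-fold lower number from compound 3 to compound 4 (0.04 log units; within the scatter), one of no real size. Compound 4 is therefore estimated at 58000 nM, between 32000 nM and 105000 nM.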

Compound 4, half-maximal cytotoxic concentration: 41200 nM
Compound 4: middle estimate off by 1.4-fold (0.15 log units), on the high side; the range from low to high includes it.
By their numbers in this assay, from the lowest: compounds 2, 4, 1 and 3 (each within the scatter of the next).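

Placing fluoro ortho to a large group and para to a fluoro group gives a 1.5-fold lower number from compound 3 to compound 4 (0.19 log units; within the scatter) in this assay, so this added atom leaves the step within the scatter. The 2,5-difluorobenzyl group also sits with both trifluorobenzyl patterns, with a 1.0-fold higher number from compound 2 to compound 4 (0.01 log units; within the scatter) and a 1.0-fold lower number from compound 1 to compound 4 (0.02 log units; within the scatter), so one, two or three fluoro groups in these arrangements cannot be told apart here. Nothing available explains why these numbers stay together.

On these data alone, what remains open is whether this ring position stays as undemanding with a group other than fluoro, such as an amine or a carboxylic acid.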